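Cytotoxicity notes: fluoro to methoxy on the pendant phenyl

This account rests on a few compounds, and the source may have more. Where it says the series, first, only, none or still open, it means among the compounds named here.

Measured so far in an ADME assay on Vero cells (Chlorocebus sabaeus) for cytotoxicity, read by MTT assay, with a stated time of 72 h; a higher number here means that more compound is tolerated, a lower number that less compound is tolerated:
- compound 1 `CCOC(=O)c1c(-c2ccc(OC)cc2)oc2ccc(OCCCN3C(=O)C(=O)c4cc(F)ccc43)cc12` gives 256000 nM
- compound 2 `CCOC(=O)c1c(-c2ccc(F)cc2)oc2ccc(OCCCN3C(=O)C(=O)c4cc(OC)ccc43)cc12` gives 128000 nM
- compound 3 `CCOC(=O)c1c(-c2ccc(F)cc2)oc2ccc(OCCCN3C(=O)C(=O)c4ccccc43)cc12` gives 256000 nM

Compound 3 stands level with compound 1 at the digits read, the two together at the top of the three numbers; compound 2 sits the furthest away, and that gap is still within the scatter. Among the measured compounds shown here, the only single-point step measured is a 2.0-fold higher number from compound 2 to compound 3 (0.30 log units; within the scatter), and it does not reach beyond the scatter either.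

Compound 4 `CCOC(=O)c1c(-c2ccc(OC)cc2)oc2ccc(OCCCN3C(=O)C(=O)c4ccccc43)cc12` differs from compound 3 by methoxy in place of fluoro on an aromatic carbon. For the measured compounds named here, no measured step changes the fluoro group on this phenyl ring, so the step has no direct precedent. What the data do show is that compound 1, which carries the 4-methoxyphenyl, and compound 3, which carries the 4-fluorophenyl, return the same number in this assay, while differing elsewhere in the molecule as well. Nothing here points to a shift in tolerated concentration beyond the scatter.

Accordingly compound 4 is expected to give 256000 nM, with a range of 128000 nM to 512000 nM; the step this implies, no change at the digits printed from compound 3 to compound 4 (within the scatter), is estimated to be nil beyond the scatter.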

Compound 4, half-maximal cytotoxic concentration: 64000 nM
For compound 4 the middle estimate is 4.0-fold (0.60 log units) above the measured one; measured number outside the range, below it.
By their numbers in this assay, from the lowest: compounds 4, 2, 1 and 3 (each within the scatter of the next, the first and the last beyond it).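

In this assay, among the compounds shown here, the change from 4-fluorophenyl to 4-methoxyphenyl gives a 4.0-fold lower number from compound 3 to compound 4 (0.60 log units; beyond the scatter), which shows that this position can move the tolerated concentration beyond the scatter, something no earlier step did. Hydrogen in place of fluoro at the other aromatic site gives a 4.0-fold lower number from compound 1 to compound 4 (0.60 log units; beyond the scatter), so both steps into compound 4 lower the number by the same amount, although compound 2, which also keeps a fluoro group, gives 128000 nM and stands against any general reading that a fluoro group alone sets the level. The measurements at hand offer no explanation for either step.

Still open, going by these compounds, is whether the lower number at this position follows from the methoxy group itself or from the loss of fluoro, a question that a chloro, methyl or hydroxy group at the same place on the phenyl ring would help to separate. Also open, on these data alone, is whether either step keeps its size on a series with a longer chain or with an amine in place of the ethyl ester.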